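A few compounds are considered here, and "the series" means these few. Any claim that something is new, unique, unknown or untested is made for them only; others in the source may bear on it.

Working notes on the series. Within the data shown here, compound 2 `COc1ccc(-c2cc(C(=O)/C=C/c3cc(OC)c(OC)c(OC)c3)nc3cc(-c4ccccc4)nn23)cc1OC` stands lowest of the two numbers so far in a functional assay on A549 cells (Homo sapiens) for antiproliferative activity, read by MTT assay, with a stated time of 24 h (a higher number here means a weaker inhibitor, a lower number a stronger inhibitor), giving 15400 nM; its nearest neighbour is compound 1 `COc1cc(/C=C/C(=O)c2cc(-c3cc(OC)c(OC)c(OC)c3)n3nc(-c4ccccc4)cc3n2)cc(OC)c1OC`, which in this assay gives 25900 nM, and the only measured step, a 1.7-fold lower number from compound 1 to compound 2 (0.23 log units; within the scatter), is a hydrogen in place of methoxy on an aromatic carbon and lies within the scatter. Compound 3 `COc1ccc(-c2cc(C(=O)/C=C/c3ccccc3)nc3cc(-c4ccccc4)nn23)cc1OC` is not yet measured in this assay. It differs from compound 2 by phenyl in place of 3,4,5-trimethoxyphenyl on a double-bonded chain carbon bound to a double-bonded chain carbon, so the change sits on the double-bonded chain rather than on the aryl where the measured step occurred, and that step bears on it only loosely. Among the measured compounds shown here, with no step at this place to guide, a change removing three acceptors is expected to shift the number more than the one measured step did, toward a weaker inhibitor, so the step of a 1.9-fold higher number from compound 2 to compound 3 (0.29 log units; within the scatter) is expected. Compound 3 is therefore estimated at 30000 nM, with a range from 11000 nM to 85000 nM.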

Compound 3, half-maximal inhibitory concentration: 18600 nM
The estimate for compound 3 lay 1.6-fold (0.21 log units) above the measured number, within the range that was stated.
By their numbers in this assay, from the lowest: compounds 2, 3 and 1 (each within the scatter of the next).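

In this assay, the step at this place, phenyl in place of 3,4,5-trimethoxyphenyl on a double-bonded chain carbon bound to a double-bonded chain carbon, is a 1.2-fold higher number from compound 2 to compound 3 (0.08 log units; within the scatter). Among the compounds shown, this is the first reading at this place, and the assay does not separate the two groups there, even though the group that leaves carries 3 hydrogen-bond acceptors and the phenyl that enters carries none. Nothing measured here offers an explanation for this result.

The compounds shown leave open whether any change at this place can produce a step beyond the scatter, for example a dimethylamino group or a carboxylic acid on the phenyl. They also leave open whether the same result would hold with the other aryl of compound 1 in place.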